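The source may report more compounds than this note shows. Statements on the series, on what has been measured and on what is new or still open speak of the compounds shown alone.

Three compounds have been measured in a functional assay on Bel-7402 cells (Homo sapiens) for antiproliferative activity, read by MTT assay, with a stated time of 72 h; on this read-out higher numbers stand for weaker inhibition and lower numbers for stronger inhibition:
compound 1 `COc1cccc(CNCc2c(C(=O)O)n(Cc3ccc(O)cc3)c3cc(C(C)C)ccc23)c1` gives 7080 nM;
compound 3 `COc1cccc(CNCc2c(C(=O)O)n(Cc3ccccc3)c3cc(C(C)C)ccc23)c1` gives 5900 nM;
compound 2 `COc1ccc(Cn2c(C(=O)O)c(CNCc3cc(OC)ccc3O)c3ccc(C)cc32)cc1` gives only a limit, > 50000 nM, and no number.

From compound 1 to compound 3 the change is hydrogen in place of hydroxy on an aromatic carbon, and it makes a 1.2-fold lower number from compound 1 to compound 3 (0.08 log units; within the scatter). Compound 4 `COc1ccc(Cn2c(C(=O)O)c(CNCc3cccc(OC)c3)c3ccc(C)cc32)cc1` has not been measured; it arises from compound 2 by hydrogen in place of hydroxy on an aromatic carbon. The surroundings differ: in compound 1 the hydroxy sits para to a large group, in compound 2 ortho to a large group and para to a methoxy group, so this is the same kind of change rather than the same change. The difference between the two cores is not broken down here. Compound 2 is known only as a limit in this assay. The step to compound 4 is expected to be about an at least 1.2-fold lower number from compound 2 to compound 4 (0.09 log units; that floor lies within the scatter), an estimate resting on a 1.2-fold lower number from compound 1 to compound 3 (0.08 log units; within the scatter). Compound 4 is therefore expected near 40000 nM, between 10000 nM and 150000 nM.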

Compound 4, half-maximal inhibitory concentration: 9830 nM
For compound 4 the middle estimate is 4.1-fold (0.61 log units) above the measured one; the whole stated range lies above it.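

In this assay the same change gives an at least 5.0-fold lower number from compound 2 to compound 4 (0.70 log units; beyond the scatter), so its size did not carry over unchanged from one core to the other: the same change on two cores in this assay, a 1.2-fold lower number (0.08 log units; within the scatter) from compound 1 to compound 3 and an at least 5.0-fold lower number (0.70 log units; beyond the scatter) from compound 2 to compound 4, at least 4.2-fold (0.62 log units) apart, beyond the scatter of two such steps
The value of compound 2, > 50000 nM, is a limit and not a number, so this step has only a floor and its full size stays unknown: the limit of > 50000 nM in this assay, at which 1 of the 4 values shown sits.
The two pairs differ both in their cores and in the surroundings of the hydroxy, and these compounds do not show which of those differences accounts for the gap.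

The compounds shown leave open whether a fluorine or an amino group in place of the hydroxy would behave in the same way on either core. They also leave open what an amide or a methyl ester in place of the carboxylic acid would do.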